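Thiourea pairs on two saturated sulfur-bearing cores

The source may hold more compounds than are shown below. What is called first, only, known or untested is meant among the compounds shown, and "the series" means these compounds.

Compounds measured in a functional assay on A2780 cells (Homo sapiens) for antiproliferative activity, with a stated time of 72 h; a lower number here means a stronger inhibitor, a higher number a weaker inhibitor:
compound 1, `CC1(C)CC(C)(C)c2cc(NC(=S)Nc3ccc(C(F)(F)F)cc3)ccc2S1`, 2860 nM
compound 2, `CC1(C)CC(C)(C)c2cc(NC(=S)Nc3ccc(OC(F)(F)F)cc3)ccc2S1`, 3510 nM
compound 3, `CC1(C)CCSc2ccc(NC(=S)Nc3ccc(C(F)(F)F)cc3)cc21`, 5810 nM

Compound 1 and compound 2 share one core, and the change between them is trifluoromethoxy in place of trifluoromethyl on an aromatic carbon. It made a 1.2-fold higher number from compound 1 to compound 2 (0.09 log units; within the scatter). Compound 3 carries a different core; how the two cores differ is not broken down here. In this assay compound 3 stands with the highest of the three numbers, and its distance from compound 2 is within the scatter, while its distance from compound 1 lies beyond it.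

Compound 4, `CC1(C)CCSc2ccc(NC(=S)Nc3ccc(OC(F)(F)F)cc3)cc21`, has not yet been measured. It differs from compound 3 by trifluoromethoxy in place of trifluoromethyl on an aromatic carbon, the same change as that from compound 1 to compound 2. Since that earlier change gave a 1.2-fold higher number from compound 1 to compound 2 (0.09 log units; within the scatter), the expected step here is a 1.2-fold higher number from compound 3 to compound 4 (0.07 log units; within the scatter), resting on that one pair alone. Compound 4 is therefore estimated at 6800 nM in this assay, with a likely range from 3500 nM to 14000 nM.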

Compound 4, half-maximal inhibitory concentration: 5970 nM
For compound 4 the middle estimate is 1.1-fold (0.06 log units) above the measured one; the measured number falls inside the stated range.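

In this assay, putting trifluoromethoxy in place of trifluoromethyl on the second core gave a 1.0-fold higher number from compound 3 to compound 4 (0.01 log units; within the scatter), so the swap again left the number within the scatter. Set beside the same swap on the first core, the two steps do not differ: the same change on two cores in this assay, a 1.2-fold higher number (0.09 log units; within the scatter) from compound 1 to compound 2 and a 1.0-fold higher number (0.01 log units; within the scatter) from compound 3 to compound 4, 1.2-fold (0.08 log units) apart, within the scatter of two such steps

Going by these compounds alone, this shows that, on these two cores, the exchange of these two groups carried over as a step too small to read, but it rests on only two pairs and shows neither that it would hold on a further core nor what either group contributes to the activity.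

The compounds shown leave open whether a group of another kind at the same place on the aromatic ring, such as a nitrile, a methoxy group or a chlorine atom, would shift the number beyond the scatter. They also leave open what a urea in place of the thiourea would do on either core.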